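Stereoinversion of a difluoro aryl urea in a plant assay

The source may report more compounds than this note shows. Statements on the series, on what has been measured and on what is new or still open speak of the compounds shown alone.

Measured so far:
compound 1 `C[C@H](NC(=O)Nc1ccc(F)cc1)c1ccccc1` — 85%
compound 2 `C[C@@H](NC(=O)Nc1ccc(F)c(F)c1)c1ccccc1` — 96%

In an ADME assay on the whole organism with Oryza sativa as the target, tested at 10 uM (a lower number here means a stronger effect, a higher number a weaker effect of the compound at the concentration tested), compound 2 gives 96%. This is the higher of the two numbers in hand; compound 1 gives 85%, a value that lies beyond the usual scatter below that of compound 2. Compound 1 and compound 2 differ in more than one place, so the two values only show that the pair are apart; no single cause can be read from them.

Compound 3 `C[C@H](NC(=O)Nc1ccc(F)c(F)c1)c1ccccc1` has not been measured in this assay. It is related to compound 2 as follows: the two compounds have the same atoms and bonds and differ only in configuration as drawn: 1 of 1 stereo elements differ; a stereocentre at a saturated chain carbon is drawn R in compound 2 and S in compound 3. Among the compounds with values here, no comparable single-change pair exists among the measured compounds, so the size of the step is open. Given that the compound with the same configuration as compound 3, compound 1, gives 85%, a small move downward is expected, but one that may well stay within the scatter. Compound 3 is therefore estimated at 90%, with a range from 75% to 100%. This estimate implies a step of a number 6 percentage points lower from compound 2 to compound 3 (within the scatter).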

Compound 3, a percentage reported as activity, at one concentration (the size of the read-out at that concentration, not a potency): 98%
Estimate against measurement, compound 3: 8 percentage points below, within the range that was stated.
By their numbers in this assay, from the lowest: compound 1; then compounds 2 and 3 (each within the scatter of the next).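

In this assay, the stereocentre at the saturated chain carbon now has a direct test: drawing it S in place of R gives a number 2 percentage points higher from compound 2 to compound 3 (within the scatter), so this pair shows no readable dependence on configuration at this position. With the S configuration held, fluoro in place of hydrogen on an aromatic carbon gives a number 13 percentage points higher from compound 1 to compound 3 (beyond the scatter), a modest step towards a weaker effect in this assay and the only step shown that lies beyond the scatter. The reading of the first pair as a test of configuration alone rests on one point: the fact that compounds 2 and 3 differ only in the configuration as drawn.

On these data alone, each of these two changes is represented by a single pair, so it remains open whether the fluoro step would also appear with the stereocentre drawn R, and whether either finding holds on a different urea partner. Also open, as far as these compounds go, is how a chloro group, a methoxy group, an amine or a carboxylic acid at that aromatic carbon would read in this assay, and whether a longer chain at the stereocentre would leave configuration equally unreadable there.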